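From Ethoxy to Methyl at the Edge of Detection

The source may report more compounds than this note shows. Statements on the series, on what has been measured and on what is new or still open speak of the compounds shown alone.

Compound 1, `COc1ccccc1Nc1nc(SCc2ccc(C(F)(F)F)cc2)nc2ccccc12`, gives > 50000 nM in a functional assay on MGC-803 cells (Homo sapiens) for cytotoxicity, read by MTT assay, with a stated time of 72 h; a lower number here means a stronger inhibitor, a higher number a weaker inhibitor.
Compound 2, `CCOc1ccccc1Nc1nc(SCc2ccc(C(F)(F)F)cc2)nc2ccccc12`, gives > 50000 nM in this assay.

The value of compound 1 is a limit of the assay, not a number. The same holds for compound 2. So the step that the two limits leave unreadable from compound 1 to compound 2 cannot be read, which is what the limit of > 50000 nM in this assay, at which 2 of the 2 values shown sit, records, and compound 2 stands only at that limit. Compound 3, `Cc1ccccc1Nc1nc(SCc2ccc(C(F)(F)F)cc2)nc2ccccc12`, differs from compound 2 by methyl in place of ethoxy on an aromatic carbon. No readable measured step bears on this change. The step that the limit leaves unreadable from compound 2 to compound 3 is expected to stay within the scatter, with compound 3 again at the limit. Compound 3 is therefore estimated at 60000 nM, ranging from 15000 nM to 200000 nM.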

Compound 3, half-maximal inhibitory concentration: 24400 nM
For compound 3 the middle estimate is 2.5-fold (0.39 log units) above the measured one; the measured number falls inside the stated range.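

In this assay, this aromatic carbon gives the first readable change: methyl in place of ethoxy gives an at least 2.0-fold lower number from compound 2 to compound 3 (0.31 log units; beyond the scatter), and methyl in place of methoxy gives an at least 2.0-fold lower number from compound 1 to compound 3 (0.31 log units; beyond the scatter). The group at this place can therefore move the result, which the unreadable step between compound 1 and compound 2 could not show. Both sizes are only minimum sizes, set by a limit of the assay: the limit of > 50000 nM in this assay, at which 2 of the 3 values shown sit.

As far as these compounds go, how far compound 3 truly lies from compound 1 and compound 2 stays open. So does the effect of a hydroxy group, an amine or a longer carbon chain at this place.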